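The source may hold more compounds than are shown below. What is called first, only, known or untested is meant among the compounds shown, and "the series" means these compounds.

In an ADME assay on a cell-free system (plasma, Rattus norvegicus) for protein binding, using equilibrium dialysis (on this read-out higher numbers stand for a larger free fraction and lower numbers for a smaller free fraction), compound 1 `O=S(=O)(c1ccc(F)cc1)c1cc(Cl)c(O)c2ncccc12` gives 0.5 and compound 2 `O=S(=O)(c1cc(Cl)c(O)c2ncccc12)C1CCCC1` gives 0.5. Compound 3 `O=S(=O)(c1cc(F)c(O)c2ncccc12)N1CCCC1` gives 0.6, within the scatter of both others. Compound 4 `O=S(=O)(c1cc(Cl)c(O)c2ncccc12)N1CCCC1` has chloro in place of fluoro on an aromatic carbon, ortho to a hydroxy group: chloro in place of fluoro on an aromatic carbon. For the measured compounds named here, no measured step covers this exchange. Going by the values given here, the only measured step, cyclopentyl in place of 4-fluorophenyl on a sulfonyl sulfur, keeps the chloro and shows no change at the digits printed from compound 1 to compound 2 (within the scatter). It bears on the exchange only indirectly, and no change beyond the scatter is expected in this assay. The estimated step is a 1.2-fold lower number from compound 3 to compound 4 (0.08 log units; within the scatter). Compound 4 is expected at 0.5, with an estimated range of 0.3 to 0.7.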

Compound 4, unbound fraction: 0.5
The estimate for compound 4 equals the measured number at the digits printed; measured number inside the range.
By their numbers in this assay, from the lowest: compounds 1, 2, 4 and 3 (each within the scatter of the next).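

In this assay, chloro in place of fluoro on an aromatic carbon, ortho to a hydroxy group, now has a direct reading (a 1.2-fold lower number from compound 3 to compound 4 (0.08 log units; within the scatter)). With the chloro kept, pyrrolidin-1-yl in place of cyclopentyl on the sulfonyl sulfur (no change at the digits printed from compound 2 to compound 4 (within the scatter)) and pyrrolidin-1-yl in place of 4-fluorophenyl (no change at the digits printed from compound 1 to compound 4 (within the scatter)) also stay within the scatter, so compounds 1, 2 and 4 do not separate. No evidence bears on this result. Open: whether bromo or methyl at this position, or a carboxylic acid or an amine on a longer chain at the sulfonyl sulfur, would move the free fraction beyond the scatter.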